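The compounds below may be only part of what the source reports. "The series", "measured", "known", "first", "only" and "open" are said of these compounds alone.

Measured compounds:
compound 1 `O=C1OC(c2ccccc2)CN1c1cnn2c1CN(C(=O)Nc1cc(F)c(F)c(F)c1)C(C1CC1)C2` – 7410 nM
compound 2 `CC1CCn2ncc(N3CC(c4ccccc4)CC3=O)c2CN1C(=O)Nc1cc(F)c(F)c(F)c1` – > 2000 nM
compound 3 `N#CC1CC(=O)N(c2cnn3c2CN(C(=O)Nc2cc(F)c(F)c(F)c2)C(C2CC2)C3)C1` – > 200000 nM

Among the measured compounds shown here, in a toxicity assay on HepG2 2.2.15 cells (Homo sapiens) for cytotoxicity, read by CellTiter-Glo (a higher number here means that more compound is tolerated, a lower number that less compound is tolerated), compound 1 gives 7410 nM, the only outright number among the three. For compound 2 the entry is a limit of the assay, not a number (the limit of > 2000 nM in this assay, at which 1 of the 3 values shown sits). For compound 3 the entry is likewise a limit (the limit of > 200000 nM in this assay, at which 1 of the 3 values shown sits). Compound 4 `Cc1nc(C2CC(=O)N(c3cnn4c3CN(C(=O)Nc3cc(F)c(F)c(F)c3)C(C3CC3)C4)C2)no1` differs from compound 1 in one place: 4-(5-methyl-1,2,4-oxadiazol-3-yl)-2-oxopyrrolidin-1-yl in place of 2-oxo-5-phenyl-1,3-oxazolidin-3-yl on an aromatic carbon. For the measured compounds named here, one measured step bears on this: an at least 26-fold higher number from compound 1 to compound 3 (1.43 log units; beyond the scatter), where the same group left and a smaller substituted 2-oxopyrrolidin-1-yl entered. Compound 4 carries a related 2-oxopyrrolidin-1-yl, so a step of similar direction in this assay is expected, likely large. Compound 4 is therefore estimated at 60000 nM, expected between 12000 nM and 200000 nM, an expected step of an 8.1-fold higher number from compound 1 to compound 4 (0.91 log units; beyond the scatter).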

Compound 4, half-maximal cytotoxic concentration: > 200000 nM
Compound 4: a limit, no number; the forecaster's own chance of this, stated with the estimate: 40%; middle value at least 3.3-fold (0.52 log units) away from the limit.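

Replacing the 2-oxo-5-phenyl-1,3-oxazolidin-3-yl with 4-(5-methyl-1,2,4-oxadiazol-3-yl)-2-oxopyrrolidin-1-yl in this assay gives an at least 26-fold higher number from compound 1 to compound 4 (1.43 log units; beyond the scatter). The entering group has the same count of heavy atoms as the group that leaves, so a large step at this position does not require a smaller group, as the change to compound 3 might have suggested. Compound 4 gives a limit of the assay, not a number: the limit of > 200000 nM in this assay, at which 2 of the 4 values shown sit.

The step between compound 3 and compound 4 cannot be read, since both entries are limits. Going by these compounds, how a carboxylic acid or an amine on the same saturated ring carbon would fare remains open.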